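The source may report more compounds than this note shows. Statements on the series, on what has been measured and on what is new or still open speak of the compounds shown alone.

Measured so far:
- compound 1 `COc1ccc(NC(=O)[C@H]2CCCN2C(=O)C2(c3ccc(Cl)cc3)CCCC2)cc1`: in an assay on isolated protein for inhibition of histone acetyltransferase p300 (Homo sapiens), with a stated time of 60 min (on this read-out lower numbers stand for stronger inhibition and higher numbers for weaker inhibition), compound 1 gives 7.94 nM
- compound 2 `COc1ccc(NC(=O)[C@H]2CCCN2C(=O)C2(c3cccc(Cl)c3)CCCC2)cc1`: in this assay compound 2 gives 100 nM
- compound 3 `CNC(=O)c1cccc(CNC(=O)[C@H]2CCCN2C(=O)C2(c3ccc(Cl)cc3)CCCC2)c1`: not yet measured in this assay

Within the data shown here, compound 1 gives the lowest of the two numbers recorded; the only other compound, compound 2, sits at a 13-fold higher number from compound 1 to compound 2 (1.10 log units; beyond the scatter), a change arising from 3-chlorophenyl in place of 4-chlorophenyl on a saturated ring carbon.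

The step to compound 3 is a different one: 3-(methylcarbamoyl)benzyl in place of 4-methoxyphenyl on an amide-type nitrogen. Among the measured compounds shown here, the measured step concerns the chlorophenyl on the saturated ring and leaves the amide nitrogen untouched, so it bears only indirectly on this change; no measured pair speaks to the amide substituent. The change is substantial in size and character, and on that basis a moderate weakening is expected, with wide uncertainty, as a 3.8-fold higher number from compound 1 to compound 3 (0.58 log units; beyond the scatter). For compound 3 the estimate in this assay is 30 nM, within 5 nM to 250 nM.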

Compound 3, half-maximal inhibitory concentration: 10 nM
For compound 3 the middle estimate is 3.0-fold (0.48 log units) above the measured one; the range from low to high includes it.
By their numbers in this assay, from the lowest: compounds 1 and 3 (each within the scatter of the next); then compound 2.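

In this assay, the step at the amide-type nitrogen reads a 1.3-fold higher number from compound 1 to compound 3 (0.10 log units; within the scatter), so this position accepts 3-(methylcarbamoyl)benzyl in place of 4-methoxyphenyl with no change beyond the scatter, even though the entering group has more heavy atoms and adds a hydrogen-bond donor. The series is therefore far less sensitive to this exchange than to the chlorine shift on the chlorophenyl, a 13-fold higher number from compound 1 to compound 2 (1.10 log units; beyond the scatter). No supporting measurement bears on this result.

Among these compounds, it remains open whether the outcome rests on the methylcarbamoyl group or on the benzyl part, as the single exchange alters both. As far as these compounds go, a plain benzyl, or a carboxylic acid or primary amine in place of the methylcarbamoyl, would separate these, and the 3-chlorophenyl step remains untested alongside 3-(methylcarbamoyl)benzyl.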